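Amino in place of chloro on compound 2

This account rests on a few compounds, and the source may have more. Where it says the series, first, only, none or still open, it means among the compounds named here.

Among the measured compounds shown here, in a functional assay on RBL-2H3 cells (Rattus norvegicus) for inhibition, read by neutral red uptake, with stated times of 30 min and 1 h (a higher number here means a weaker inhibitor, a lower number a stronger inhibitor), compound 1 (`COc1ccc(CN(CCN(C)C)c2ccccc2)cc1`) gives 143 nM and compound 2 (`COc1ccc(CN(CCN(C)C)c2ccc(Cl)cc2)cc1`) gives 18.1 nM, the lowest of the two numbers so far. The next compound, compound 3 (`COc1ccc(CN(CCN(C)C)c2ccc(N)cc2)cc1`), has amino in place of chloro on an aromatic carbon, a change counted as amino in place of chloro on an aromatic carbon and not yet measured. For the measured compounds named here, the one measured step that bears on it is a 7.9-fold lower number from compound 1 to compound 2 (0.90 log units; beyond the scatter) with chloro in place of hydrogen on an aromatic carbon. Going by the values given here, no measured compound carries amino, so the nearest guide is compound 1 at 143 nM and a step of comparable size toward a higher number is expected in this assay for this change. The expected change is a 7.7-fold higher number from compound 2 to compound 3 (0.89 log units; beyond the scatter) by this estimate. For compound 3 the estimate is 140 nM, with an expected range of 40 nM to 500 nM in this reading.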

Compound 3, half-maximal inhibitory concentration: 2310 nM
Beside the measured number, compound 3's estimate is 17-fold (1.22 log units) below it; measured number above the stated range.
By their numbers in this assay, from the lowest: compound 2; then compound 1; then compound 3.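

In this assay the place on the aromatic ring para to a large group proves sensitive in both directions: where chloro gave a 7.9-fold lower number from compound 1 to compound 2 (0.90 log units; beyond the scatter), amino in place of hydrogen gives a 16-fold higher number from compound 1 to compound 3 (1.21 log units; beyond the scatter) instead. Exchanging a single heavy atom, with one hydrogen-bond donor and one hydrogen-bond acceptor entering, therefore gives a 130-fold higher number from compound 2 to compound 3 (2.11 log units; beyond the scatter), the largest step among these three compounds. Nothing given here accounts for this gap between chloro and amino.

The compounds shown leave open whether a hydroxyl or an acetamide at this place would stand nearer to amino or to chloro, and whether fluoro or bromo would track chloro. They also leave open whether a methylamino or dimethylamino group would keep the number as high as amino does.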